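Cyclohexylbenzimidazoles: amide replaces carbamate, Vero cytotoxicity expected

This account rests on a few compounds, and the source may have more. Where it says the series, first, only, none or still open, it means among the compounds named here.

Compound 1 `CCN(CC)c1cc2[nH]c(C3CCCCC3)nc2cc1NC(=O)NCc1ccccc1` stands at the limit > 100 ug/mL in an ADME assay on Vero cells (Chlorocebus sabaeus) for cytotoxicity, read by resazurin assay, with a stated time of 3 days; a higher number here means a weaker inhibitor, a lower number a stronger inhibitor.
Compound 2 `CCCCOC(=O)Nc1cc2nc(C3CCCCC3)[nH]c2cc1N(C)C` stands at the limit > 100 ug/mL in this assay.
Compound 3 `CCCCOC(=O)Nc1cc2nc(C3CCCCC3)[nH]c2cc1N(CC)CC` stands at the limit > 100 ug/mL in this assay.

All three measured compounds share one core carrying a cyclohexyl group, and none of them gives a number in this assay: each result is a limit only. Compound 3 therefore cannot be placed above or below its neighbours; it simply sits where the other two sit, as the line the limit of > 100 ug/mL in this assay, at which 3 of the 3 values shown sit, shows. Two measured steps lead into compound 3. The step that the two limits leave unreadable from compound 1 to compound 3 and the step that the two limits leave unreadable from compound 2 to compound 3 are both unreadable, since both ends are limits, so neither tells how large a change in this position or the other can be.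

Compound 4 `CCN(CC)c1cc2[nH]c(C3CCCCC3)nc2cc1NC(=O)c1ccc(Br)cc1` is not yet measured. Relative to compound 3 the change is 4-bromophenyl in place of butoxy on a carbonyl carbon. Going by the values given here, no measured step speaks to this change, so no direction beyond the scatter can be read from the data. Compound 4 is estimated at 100 ug/mL, between 35 ug/mL and 300 ug/mL. The step this estimate means is expected to be a number no higher from compound 3 to compound 4 (the limit leaves the size open), with a fair chance that only a limit is again reported.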

Compound 4, half-maximal inhibitory concentration: > 100 ug/mL
Compound 4: a limit, no number (the forecaster's own chance of this, stated with the estimate: 60%); the middle value sits exactly at the limit.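

Compound 4 also gives only a limit in this assay, so the steps into it from compound 3 and compound 1 cannot be read: the limit of > 100 ug/mL in this assay, at which 4 of the 4 values shown sit.

The compounds shown leave open whether any change on the carbonyl carbon shifts cytotoxicity in this assay at all.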